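The compounds below may be only part of what the source reports. "The series", "measured", "known", "first", "only" and "open" are said of these compounds alone.

Working notes on the series.

For the measured compounds named here, compound 2 `COc1cnc(-c2ccccn2)nc1NCc1ccccc1` gives 911 mL/min/kg in an in vitro ADME assay on microsomes from liver (Mus musculus) for metabolic stability, read by LC-MS, tested at 0.05 uM (a lower number here means slower removal, a higher number faster removal of the compound), the highest of the two numbers so far. Going by the values given here, its only neighbour is compound 1 `COc1cnc(-c2ccccn2)nc1NCc1ccccc1Cl`, which in this assay gives 704 mL/min/kg; the single measured step, a 1.3-fold higher number from compound 1 to compound 2 (0.11 log units; within the scatter), stays within the scatter, so the two values cannot be ordered.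

Compound 3 `COc1cnc(-c2ccccn2)nc1NCc1ccc(F)cc1F` is not yet measured in this assay. It differs from compound 2 by 2,4-difluorophenyl in place of phenyl on a saturated chain carbon bound to a nitrogen on an aromatic ring.

Among the compounds with values here, only one measured step bears on this change: a 1.3-fold higher number from compound 1 to compound 2 (0.11 log units; within the scatter), in which a halogen on the ring left and the number moved by an amount inside the scatter. Within the data shown here, the change to compound 3 puts two fluorine atoms onto the ring that leaves as phenyl and enters as 2,4-difluorophenyl, so the nearest precedent is the reverse of that step. The expectation is therefore a step no larger than the scatter, if anything toward a lower number, as a 1.2-fold lower number from compound 2 to compound 3 (0.08 log units; within the scatter).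

For compound 3 the estimated value in this assay is 750 mL/min/kg, expected to lie between 400 mL/min/kg and 1400 mL/min/kg.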

Compound 3, clearance: 524 mL/min/kg
Compound 3: the middle estimate sits 1.4-fold (0.16 log units) above what was measured, within the range that was stated.
By their numbers in this assay, from the lowest: compounds 3, 1 and 2 (each within the scatter of the next).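

In this assay the change to 2,4-difluorophenyl reads as a 1.7-fold lower number from compound 2 to compound 3 (0.24 log units; within the scatter) and the exchange of 2-chlorophenyl for the same group reads as a 1.3-fold lower number from compound 1 to compound 3 (0.13 log units; within the scatter) and both steps stay within the scatter. This position on a saturated chain carbon bound to a nitrogen on an aromatic ring has now carried phenyl, 2-chlorophenyl and 2,4-difluorophenyl, and every pair among the three compounds lies within the scatter, so the three groups cannot be ordered and neither the single chloro nor the two fluoro substituents separate from the unsubstituted ring on these numbers. No measurement at hand explains where these three values fall.

Whether any replacement at this position can move the number beyond the scatter stays open, since all three groups shown are halogen-bearing or plain phenyl rings and an amine or a carboxylic acid on that ring has no value here. Also open, going by these compounds, is what a longer chain between the ring and the nitrogen would do to the number on the shared core.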